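Urea to amide on an unchanged core

The source may report more compounds than this note shows. Statements on the series, on what has been measured and on what is new or still open speak of the compounds shown alone.

Compound 2 `CC(=O)Nc1ncnc2c1ccn2-c1ccc(NC(=O)Nc2cccc(Cl)c2Cl)cc1` was examined in a functional assay on A375P cells (Homo sapiens) for antiproliferative activity, read by MTT assay, with a stated time of 24 h; on this read-out lower numbers stand for stronger inhibition and higher numbers for weaker inhibition. In this assay compound 2 gives > 10000 nM, which is a limit of the assay and not a number. Its nearest neighbour, compound 1 `CC(=O)Nc1ncnc2c1ccn2-c1ccc(NC(=O)Nc2ccc(Cl)c(C(F)(F)F)c2)cc1`, differs only in the aryl group on the amide-type nitrogen. In this assay compound 1 gives > 10000 nM, again a limit rather than a number. The step that the two limits leave unreadable from compound 1 to compound 2 therefore cannot be read, because of the limit of > 10000 nM in this assay, at which 2 of the 2 values shown sit. Compound 3 `CC(=O)Nc1ncnc2c1ccn2-c1ccc(NC(=O)c2ccc(Cl)c(C(F)(F)F)c2)cc1` has not yet been measured; it differs from compound 2 by 4-chloro-3-(trifluoromethyl)phenyl in place of (2,3-dichlorophenyl)amino on a carbonyl carbon. Among the compounds with values here, no measured step bears on this change, and since both known values are limits, neither a direction nor a size can be taken from them. For compound 3 the expected value in this assay is estimated at 10000 nM, with a range from 3000 nM to 30000 nM. This estimate means an expected step of a number no higher from compound 2 to compound 3 (the limit leaves the size open), which is no change beyond the scatter.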

Compound 3, half-maximal inhibitory concentration: > 10000 nM
Compound 3 gave a limit, no number (the forecaster's own chance of this, stated with the estimate: 65%); the middle value sits exactly at the limit.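

Compound 3, like compound 2, gives only a limit in this assay, so the step between them cannot be read: the limit of > 10000 nM in this assay, at which 3 of the 3 values shown sit.

The compounds shown leave open whether any change to the groups on compound 1, compound 2 or compound 3 would give a measurable value in this assay.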